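The source may hold more compounds than are shown below. What is called first, only, known or untested is meant among the compounds shown, and "the series" means these compounds.

In a functional assay on MIA PaCa-2 cells (Homo sapiens) for cytotoxicity, read by WST assay, with a stated time of 24 h (on this read-out higher numbers stand for weaker inhibition and lower numbers for stronger inhibition), compound 1 (`N#C/C(=C\c1c[nH]c2cc(F)ccc12)C(=O)c1c[nH]c2ccccc12`) gives 23500 nM and compound 2 (`COc1ccc2c(/C=C(\C#N)C(=O)c3c[nH]c4ccccc34)c[nH]c2c1`) gives 27500 nM, so these two values lie within the usual scatter of each other. Compound 3 (`COc1ccc2[nH]cc(C(=O)/C(C#N)=C/c3c[nH]c4cc(F)ccc34)c2c1`) keeps all of compound 1 and adds one group: methoxy in place of hydrogen on an aromatic carbon. Among the measured compounds shown here, the only measured step that bears on this, a 1.2-fold higher number from compound 1 to compound 2 (0.07 log units; within the scatter), also brings in a methoxy, though in place of fluoro rather than hydrogen. No shift beyond the scatter is therefore expected in this assay, although one step is thin evidence. The expected step is a 1.1-fold higher number from compound 1 to compound 3 (0.03 log units; within the scatter). For compound 3 the estimated value is 25000 nM, with an expected range of 11000 nM to 55000 nM.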

Compound 3, half-maximal inhibitory concentration: > 50000 nM
Compound 3 ended at the assay's limit (the forecaster's own chance of this, stated with the estimate: 10%); middle value at least 2.0-fold (0.30 log units) from the limit.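

In this assay, among the compounds shown here, methoxy in place of hydrogen on this aromatic carbon gives an at least 2.1-fold higher number from compound 1 to compound 3 (0.32 log units; beyond the scatter), the first step here that lies beyond the scatter. The earlier step, a 1.2-fold higher number from compound 1 to compound 2 (0.07 log units; within the scatter), also brought in a methoxy, but in place of fluoro and elsewhere on the molecule, and it stayed within the scatter, so the effect of a methoxy depends on where it sits or what it replaces. The result for compound 3 is a limit, not a number: the limit of > 50000 nM in this assay, at which 1 of the 3 values shown sits.

From the compounds shown here alone, how much weaker compound 3 really is remains open. So does whether an amine, a carboxylic acid or a longer chain on this carbon would give the same shift.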